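Swapping 2-fluorophenyl for 4-bromophenyl on a shared core

A few compounds are considered here, and "the series" means these few. Any claim that something is new, unique, unknown or untested is made for them only; others in the source may bear on it.

Compound 1 `COc1cc2c(Oc3ccc(NC(=O)c4nn(-c5ccccc5)c(=O)c5ccccc45)cc3F)ccnc2cc1OCCCN1CCC(C)CC1` and compound 2 `COc1cc2c(Oc3ccc(NC(=O)c4nn(-c5ccccc5F)c(=O)c5ccccc45)cc3F)ccnc2cc1OCCCN1CCC(C)CC1` share one core and differ by a single atom. In a functional assay on MKN-45 cells (Homo sapiens) for cytotoxicity, read by MTT assay, with a stated time of 72 h (a higher number here means a weaker inhibitor, a lower number a stronger inhibitor), compound 1 gives 580 nM, while compound 2 gives 260 nM. That step, a 2.2-fold lower number from compound 1 to compound 2 (0.35 log units; beyond the scatter), is fluoro in place of hydrogen on an aromatic carbon. For the measured compounds named here, compound 2 therefore stands at the lower of the two numbers measured so far. Compound 3 `COc1cc2c(Oc3ccc(NC(=O)c4nn(-c5ccc(Br)cc5)c(=O)c5ccccc45)cc3F)ccnc2cc1OCCCN1CCC(C)CC1` carries 4-bromophenyl in place of 2-fluorophenyl on an aromatic nitrogen. Going by the values given here, only the step from compound 1 to compound 2 bears on this change, and only loosely, since the new ring carries bromine rather than fluorine and the halogen sits at another place on the ring; that earlier step was modest. The expected step is accordingly small, a 1.5-fold higher number from compound 2 to compound 3 (0.19 log units; within the scatter), with no clear direction beyond the scatter. Compound 3 is estimated at 400 nM in this assay, within a range from 150 nM to 1200 nM.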

Compound 3, half-maximal inhibitory concentration: 330 nM
Estimate against measurement, compound 3: 1.2-fold (0.08 log units) above; the range from low to high includes it.
By their numbers in this assay, from the lowest: compounds 2, 3 and 1 (each within the scatter of the next, the first and the last beyond it).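

In this assay the exchange of 2-fluorophenyl for 4-bromophenyl on the aromatic nitrogen gives a 1.3-fold higher number from compound 2 to compound 3 (0.10 log units; within the scatter) and so leaves the two compounds indistinguishable, even though both the halogen and its place on the ring differ. Bromo in place of hydrogen gives a 1.8-fold lower number from compound 1 to compound 3 (0.24 log units; within the scatter) and, unlike the fluoro change with a 2.2-fold lower number from compound 1 to compound 2 (0.35 log units; beyond the scatter), does not clear the scatter, so a gain from adding a halogen to this ring is shown only for the 2-fluorophenyl group. No measurement at hand offers an explanation for these numbers.

Going by these compounds, the halogen and its place on the ring change together here, so their separate contributions remain unknown. Also open, on these data alone, is how this position would respond to a group other than a halogen on the phenyl ring, such as an amine or a carboxylic acid.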